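A Phenoxy Arm Replaces the Benzyl Arm Before Testing

The source may hold more compounds than are shown below. What is called first, only, known or untested is meant among the compounds shown, and "the series" means these compounds.

Of the compounds shown here, three sharing one core have been measured in an ADME assay on HepG2 cells (Homo sapiens) for cytotoxicity, read by luminescence, CellTiter-Glo and ATP content, with a stated time of 72 h; on this read-out lower numbers stand for an effect already at smaller amounts and higher numbers for an effect only at larger amounts of compound. Compound 1 `COc1cccc(CNCCCNc2ccnc3cc(Cc4ccccc4)ccc23)c1O` gives 5720 nM, compound 2 `COc1cccc(CNCCCNc2ccnc3cc(-c4ccccc4)ccc23)c1O` gives 3210 nM, and compound 3 `COc1cccc(CNCCCNc2ccnc3cc(Cc4ccc(C#N)cc4)ccc23)c1O` gives 7150 nM. Compound 3 holds the highest of these three numbers; the step of a 1.3-fold higher number from compound 1 to compound 3 (0.10 log units; within the scatter) keeps it within the scatter of compound 1, while the step of a 2.2-fold higher number from compound 2 to compound 3 (0.35 log units; beyond the scatter) sets it apart from compound 2. The remaining step, a 1.8-fold lower number from compound 1 to compound 2 (0.25 log units; within the scatter), is also small.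

Compound 4 `COc1cccc(CNCCCNc2ccnc3cc(Oc4cccc(N(C)C)c4)ccc23)c1O` departs from compound 3 by a single change: 3-(dimethylamino)phenoxy in place of 4-cyanobenzyl on an aromatic carbon. The group that leaves is the 4-cyanobenzyl; the group that enters is the 3-(dimethylamino)phenoxy, on the same aromatic carbon of the fused two-ring system. Among the compounds with values here, no measured step covers this exchange. The steps that come closest, a 1.8-fold lower number from compound 1 to compound 2 (0.25 log units; within the scatter) and a 1.3-fold higher number from compound 1 to compound 3 (0.10 log units; within the scatter), both stay within the scatter, and even the widest one, a 2.2-fold higher number from compound 2 to compound 3 (0.35 log units; beyond the scatter), is only modest. Compound 4 is therefore expected to show a step of about a 1.4-fold lower number from compound 3 to compound 4 (0.16 log units; within the scatter), with no clear direction, and is estimated at 5000 nM, between 2000 nM and 12500 nM, in this assay.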

Compound 4, half-maximal effective concentration: 7300 nM
Beside the measured number, compound 4's estimate is 1.5-fold (0.16 log units) below it, within the range that was stated.
By their numbers in this assay, from the lowest: compounds 2, 1, 3 and 4 (each within the scatter of the next, the first and the last beyond it).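

In this assay, the exchange of 4-cyanobenzyl for 3-(dimethylamino)phenoxy on this aromatic carbon gives a 1.0-fold higher number from compound 3 to compound 4 (0.01 log units; within the scatter), so an arm joined through oxygen and carrying a dimethylamino group stays within the scatter of the 4-cyanobenzyl arm. Set against the other two arms, the same group gives a 1.3-fold higher number from compound 1 to compound 4 (0.11 log units; within the scatter) and a 2.3-fold higher number from compound 2 to compound 4 (0.36 log units; beyond the scatter), which means that compound 2 is now set apart, modestly, from both compound 3 and compound 4, but not from compound 1. No measurement shown here accounts for these numbers. The compounds shown leave open what the oxygen link and the dimethylamino group each contribute, since plain phenoxy does not appear among them. They also leave open whether a carboxylic acid or a morpholine on that ring would move the number beyond the scatter.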